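A few compounds are considered here, and "the series" means these few. Any claim that something is new, unique, unknown or untested is made for them only; others in the source may bear on it.

Measured compounds:
compound 1, `Cn1cccc1-c1cc(-c2cccs2)nc(N)c1C#N`: > 100000 nM
compound 2, `Cn1cccc1-c1cc(-c2cccs2)[nH]c(=O)c1C#N`: > 100000 nM
compound 3, `COc1ccc(-c2cc(-c3cccn3C)c(C#N)c(N)n2)cc1OC`: 67600 nM

In a functional assay on SN12C cells (Homo sapiens) for inhibition, read by sulforhodamine B assay, with a stated time of 48 h (on this read-out lower numbers stand for stronger inhibition of growth and higher numbers for weaker inhibition of growth), compound 1 gives > 100000 nM, which is a limit of the assay and not a number. Compound 2 also reaches only a limit, > 100000 nM. Compound 3 gives a number, 67600 nM. Compound 1 therefore stands at the limit of > 100000 nM in this assay, at which 2 of the 3 values shown sit, so nothing more precise than a ceiling is known for it.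

Compound 4, `Cn1cccc1-c1cc(-c2ccccc2)nc(N)c1C#N`, is not yet measured. It differs from compound 1 by phenyl in place of thiophen-2-yl on an aromatic carbon. For the measured compounds named here, no measured pair shows this change, so its effect in this assay cannot be read off any step; only the three values above are available, and none of them suggests that this change moves the value far.

Compound 4 is expected to sit near compound 1, at about 100000 nM with a range of 30000 nM to 300000 nM, most likely again as a limit. The step from compound 1 to compound 4 is thus expected to be a number no higher from compound 1 to compound 4 (the limit leaves the size open), none beyond the scatter.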

Compound 4, concentration for 50% growth inhibition: > 100000 nM
Compound 4: only a limit was reported (the forecaster's own chance of this, stated with the estimate: 70%); the middle value sits exactly at the limit.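

No step can be read between compound 1 and compound 4, as each gives only a limit of the assay and not a number: the limit of > 100000 nM in this assay, at which 3 of the 4 values shown sit.

From the compounds shown here alone, whether phenyl in place of thiophen-2-yl changes the result in this assay at all stays open, as does the actual number behind either limit.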